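A fluorophenyl swap on the shared core

This account rests on a few compounds, and the source may have more. Where it says the series, first, only, none or still open, it means among the compounds named here.

Compound 1 `Cn1cc(-c2ccccc2Oc2ccccc2)c2cc(C(=O)NCc3ccc(C(=O)Nc4ccccc4N)cc3)[nH]c2c1=O` and compound 2 `Cn1cc(-c2cccc(C(C)(C)O)c2)c2cc(C(=O)NCc3ccc(C(=O)Nc4ccccc4N)cc3)[nH]c2c1=O` share a core and carry different groups on it. In a functional assay on MV4-11 cells (Homo sapiens) for antiproliferative activity, read by CCK-8 assay, with a stated time of 72 h (on this read-out lower numbers stand for stronger inhibition and higher numbers for weaker inhibition), compound 1 gives 80 nM, while compound 2 gives 2200 nM. Compound 2 therefore has the higher of the two numbers, meaning weaker inhibition, and the gap between them lies beyond the usual scatter of repeated measurements.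

Compound 3 `Cn1cc(-c2ccccc2F)c2cc(C(=O)NCc3ccc(C(=O)Nc4ccccc4N)cc3)[nH]c2c1=O` has not yet been measured. It carries 2-fluorophenyl in place of 3-(1-hydroxy-1-methylethyl)phenyl on an aromatic carbon, two atoms from the ring nitrogen. Going by the values given here, no measured pair shows a change of this kind, so any forecast is uncertain and its range must be wide. Among the compounds with values here, the only guide is that compound 2, at 2200 nM, stands at the top of a very short series, whose other member is compound 1 at 80 nM. A step of a 7.3-fold lower number from compound 2 to compound 3 (0.87 log units; beyond the scatter) is expected, towards stronger inhibition and beyond the scatter. Compound 3 is estimated at 300 nM, with an expected range from 70 nM to 1200 nM.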

Compound 3, half-maximal inhibitory concentration: 230 nM
For compound 3 the middle estimate is 1.3-fold (0.12 log units) above the measured one; the measured number falls inside the stated range.
By their numbers in this assay, from the lowest: compound 1; then compound 3; then compound 2.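

Going by these compounds alone, replacing 3-(1-hydroxy-1-methylethyl)phenyl with 2-fluorophenyl on this aromatic carbon of the shared core, two atoms from the ring nitrogen, gives a 9.6-fold lower number from compound 2 to compound 3 (0.98 log units; beyond the scatter) in this assay, which shows that a much simpler aryl group than the one in compound 2 can still give a clearly lower number. Fluoro in place of phenoxy gives a 2.9-fold higher number from compound 1 to compound 3 (0.46 log units; beyond the scatter), so the larger phenoxy group of compound 1 gives the lowest number of the three, and this substituent on the phenyl ring changes the result by more than the usual scatter. No measurement shown here explains why either change moves the number as it does.

Compound 2 and compound 3 differ both in the substituent and in its place on the phenyl ring, so the two contributions cannot be separated, and a 3-fluorophenyl group would be needed to tell them apart. Going by these compounds, it also remains open where groups such as 2-methoxyphenyl or 2-aminophenyl would fall relative to compound 1 and compound 3, and so whether the number follows any simple trend at this position.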